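Moving the Bromine: the Same Change Across Two Cores

This account rests on a few compounds, and the source may have more. Where it says the series, first, only, none or still open, it means among the compounds named here.

Compound 1, `Fc1ccc(/C=N/Nc2nc(-c3cccc(Br)c3)cs2)cc1F`, in an ADME assay on HUVEC cells (Homo sapiens) for inhibition, read by MTT assay, with a stated time of 48 h (a higher number here means a weaker inhibitor, a lower number a stronger inhibitor), gives > 100000 nM, which is a limit of the assay rather than a number.
Compound 2, `Fc1ccc(/C=N/Nc2nc(-c3ccc(Br)cc3)cs2)cc1F`, in this assay gives > 100000 nM, again a limit of the assay.
Compound 3, `COc1cc(/C=N/Nc2nc(-c3cccc(Br)c3)cs2)c(Br)c(Br)c1OC`, in this assay gives > 100000 nM, once more a limit of the assay.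

Compound 1 and compound 2 differ by one change, (4-bromophenyl in place of 3-bromophenyl on an aromatic carbon). Because both values sit at the same limit, the step that the two limits leave unreadable from compound 1 to compound 2 cannot be read. Compound 4, `COc1cc(/C=N/Nc2nc(-c3ccc(Br)cc3)cs2)c(Br)c(Br)c1OC`, stands to compound 3 as compound 2 stands to compound 1: the difference is 4-bromophenyl in place of 3-bromophenyl on an aromatic carbon. The place described for the change around compound 3 is word for word the same as for compound 1, so this is the same change, made on a second core. How the core of compound 3 differs from the core of compound 1 is not broken down here; the two cores differ in more than one place.

Every value shown so far rests at the limit of > 100000 nM in this assay, at which 3 of the 3 values shown sit. With compound 3 itself at that limit, there is no direction for the change to push against. Compound 4 is therefore expected to show a step that the limit leaves unreadable from compound 3 to compound 4, meaning essentially no readable movement in this assay. The estimate for compound 4 in this assay is 200000 nM, with an expected range from 60000 nM to 1000000 nM, most likely reported again as a limit.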

Compound 4, half-maximal inhibitory concentration: > 100000 nM
Compound 4 gave a limit, no number (the forecaster's own chance of this, stated with the estimate: 90%); the middle value is on the limit's open side.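

Compound 3 and compound 4 both end at a limit rather than a number in this assay, so no step between them can be read, just as none could be read between compound 1 and compound 2: the limit of > 100000 nM in this assay, at which 4 of the 4 values shown sit.

The compounds shown leave open whether 4-bromophenyl in place of 3-bromophenyl changes the reading at all in this assay, and how far past the limit any of the four compounds lies.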